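The compounds below may be only part of what the source reports. "The series", "measured", "known", "first", "only" and "open" are said of these compounds alone.

Compound 1 `CCC(C)(C)Cc1c[nH]c(CCc2ccc(-c3cccc(C)n3)cc2)n1` carries a 6-methylpyridin-2-yl group and in a functional assay on HEK293 cells for agonist activity at Bombesin receptor subtype-3 (Mus musculus), read by luminescence and calcium flux, with a stated time of 10 min (a higher number here means that more compound is needed for the effect, a lower number that less compound is needed), compound 1 gives 19 nM. Among the measured compounds shown here, of the two numbers measured in this assay, compound 1 has the lowest; the nearest is compound 2 `CCC(C)(C)Cc1c[nH]c(CCc2ccc(-n3ccnn3)cc2)n1`, for which this assay reports 57 nM, and the step of a 3.0-fold higher number from compound 1 to compound 2 (0.48 log units; beyond the scatter) is the only measured step.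

Compound 3 `CCC(C)(C)Cc1c[nH]c(CCc2ccc(-c3cnccn3)cc2)n1` has not yet been measured. It differs from compound 1 in one place: pyrazin-2-yl in place of 6-methylpyridin-2-yl on an aromatic carbon

For the measured compounds named here, the one step that bears on this change, a 3.0-fold higher number from compound 1 to compound 2 (0.48 log units; beyond the scatter), comes from exchanging the same group for a five-membered ring, a larger departure from compound 1 than pyrazin-2-yl in place of 6-methylpyridin-2-yl. A step of at most that size is expected, and likely smaller, with the number for compound 3 somewhat higher than for compound 1. The step expected is a 1.8-fold higher number from compound 1 to compound 3 (0.27 log units; within the scatter). For compound 3 the estimated value in this assay is 35 nM, with a range from 14 nM to 90 nM.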

Compound 3, half-maximal effective concentration: 11 nM
Compound 3: the middle estimate sits 3.2-fold (0.50 log units) above what was measured; the measured number lies below the stated range.
By their numbers in this assay, from the lowest: compounds 3 and 1 (each within the scatter of the next); then compound 2.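

In this assay, the position on an aromatic carbon para to a large group takes pyrazin-2-yl in place of 6-methylpyridin-2-yl without a change that stands out from the scatter (a 1.7-fold lower number from compound 1 to compound 3 (0.24 log units; within the scatter)); a second hetero atom in the ring and the loss of the methyl group, taken together, leave the number where it was. The step from the five-membered ring is beyond the scatter (a 5.2-fold lower number from compound 2 to compound 3 (0.71 log units; beyond the scatter)), so among these three compounds the two six-membered aromatic rings sit together and 1H-1,2,3-triazol-1-yl stands apart. Nothing on hand accounts for these numbers.

Going by these compounds, the separate share of the methyl group and of the second ring nitrogen stays open, and an unsubstituted pyridin-2-yl would divide the two. On these data alone, how far this position tolerates a non-aromatic group, such as an amine or a carboxylic acid, also stays open.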